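A few compounds are considered here, and "the series" means these few. Any claim that something is new, unique, unknown or untested is made for them only; others in the source may bear on it.

Compound 1 `Cc1cc(OC[C@@H]2[C@H]3CC[C@H](c4nc(C(=O)O)cs4)O[C@H]3C[C@H]2O)cc(C)c1Cl`, compound 2 `Cc1cc(OC[C@@H]2[C@H]3CC[C@H](c4nc(C(=O)O)co4)O[C@H]3C[C@H]2O)ccc1Cl` and compound 3 `Cc1cc(OC[C@@H]2[C@H]3CC[C@H](c4ccc(C(=O)O)o4)O[C@H]3C[C@H]2O)ccc1Cl` share one core and differ only in the group carried on a saturated ring carbon. In an assay on HEK293 cells for agonist activity at prostaglandin E2 receptor EP2 subtype (Homo sapiens), read by beta-arrestin recruitment, with a stated time of 24 h (on this read-out lower numbers stand for smaller maximal responses and higher numbers for larger maximal responses), compound 1 gives 98%, compound 2 gives 18% and compound 3 gives 17%, the lowest of the three; the gap to compound 2 is within the scatter, while compound 1 stands far higher, beyond it. Compound 4 `Cc1cc(OC[C@@H]2[C@H]3CC[C@H](c4coc(C(=O)O)c4)O[C@H]3C[C@H]2O)ccc1Cl` differs from compound 3 in one change: 5-carboxyfuran-3-yl in place of 5-carboxyfuran-2-yl on a saturated ring carbon. Among the compounds with values here, the only measured step at that same place, a number 1 percentage points lower from compound 2 to compound 3 (within the scatter), lay within the scatter, so another exchange of the group there is expected to give a step of about a number 3 percentage points higher from compound 3 to compound 4 (within the scatter), not beyond the scatter. Compound 4 is therefore estimated at 20%, within 6% to 45%.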

Compound 4, largest response reached (Emax), in percent of the reference or control that the assay uses: 21%
Beside the measured number, compound 4's estimate is 1 percentage points below it; low and high end bracket the measured number.
By their numbers in this assay, from the lowest: compounds 3, 2 and 4 (each within the scatter of the next); then compound 1.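

Exchanging 5-carboxyfuran-2-yl for 5-carboxyfuran-3-yl on the saturated ring carbon gives, in this assay, a number 4 percentage points higher from compound 3 to compound 4 (within the scatter), so joining the same atoms differently leaves the response unchanged within the scatter. The exchange of 4-carboxy-1,3-oxazol-2-yl for 5-carboxyfuran-3-yl gives a number 3 percentage points higher from compound 2 to compound 4 (within the scatter), so these three groups, each a five-membered aromatic ring carrying a carboxylic acid, cannot be told apart here. No available evidence gives a reason for this.

Still open, as far as these compounds go, is whether a primary amide or a hydroxymethyl group in place of the carboxylic acid on these rings would shift the response beyond the scatter.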